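The source may report more compounds than this note shows. Statements on the series, on what has been measured and on what is new or still open speak of the compounds shown alone.

Compound 3, `COc1cc(NC(=O)Nc2cc(Nc3ccc(Br)cc3OC)ncn2)cc(OC)c1`, gives 25.7% in a functional assay on NCI-H226 cells (Homo sapiens) for inhibition, read by MTT assay, with a stated time of 48 h, tested at 10 uM (on this read-out lower numbers stand for less inhibition and higher numbers for more inhibition at the one concentration tested (going by the name of the read-out)), the lowest of the three numbers shown. Compound 2, `COc1cc(NC(=O)Nc2cc(Nc3ccc(F)c(Cl)c3)ncn2)cc(OC)c1`, gives 36.7% in this assay, and compound 1, `COc1cc(NC(=O)Nc2cc(Nc3cccc(C(C)(C)C)c3)ncn2)cc(OC)c1`, gives 40%. The two steps that end at compound 3 both fall beyond the scatter: a number 14.3 percentage points lower from compound 1 to compound 3 (beyond the scatter) and a number 11 percentage points lower from compound 2 to compound 3 (beyond the scatter), while a number 3.3 percentage points lower from compound 1 to compound 2 (within the scatter) stays within it. Compound 4, `CCc1ccc(Nc2cc(NC(=O)Nc3cc(OC)cc(OC)c3)ncn2)cc1`, differs from compound 3 by 4-ethylphenyl in place of 4-bromo-2-methoxyphenyl on a nitrogen on an aromatic ring. Since each change of the aryl group on that nitrogen away from 4-bromo-2-methoxyphenyl was accompanied by a modestly higher number, a modest rise is expected for compound 4, about a number 9.3 percentage points higher from compound 3 to compound 4 (within the scatter). Compound 4 is therefore estimated at 35%, between 20% and 50%.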

Compound 4, a percentage reported as inhibition, at one concentration (the size of the read-out at that concentration, not a potency): 50.1%
The estimate for compound 4 lay 15.1 percentage points below the measured number; measured number outside the range, above it.
By their numbers in this assay, from the lowest: compound 3; then compounds 2 and 1 (each within the scatter of the next); then compound 4.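

In this assay, 4-ethylphenyl on the nitrogen gives a higher number than each of the three earlier aryl groups, with a number 24.4 percentage points higher from compound 3 to compound 4 (beyond the scatter) and a number 13.4 percentage points higher from compound 2 to compound 4 (beyond the scatter) and a number 10.1 percentage points higher from compound 1 to compound 4 (beyond the scatter) as the steps. Among these compounds, the position therefore allows a higher number than the earlier compounds reached, and the group that does so has only carbon among its heavy atoms. No measurement shown explains this rise.

As far as these compounds go, whether the ethyl group itself matters remains open. A longer chain, an amine or a carboxylic acid in its place would test this.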